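A few compounds are considered here, and "the series" means these few. Any claim that something is new, unique, unknown or untested is made for them only; others in the source may bear on it.

Compound 1, `O=C1C(N2CCCCC2)=CC(=O)c2c1nc1n2[C@H]2OC[C@@H](O)[C@H]2OC1`, in a functional assay on ECa-109 cells for inhibition, with ECa-109 cell line (Homo sapiens) as the target, read by sulforhodamine B assay; a lower number here means a stronger inhibitor, a higher number a weaker inhibitor: > 8000 nM
Compound 2, `Cc1ccc(NC2=CC(=O)c3c(nc4n3[C@H]3OC[C@@H](O)[C@H]3OC4)C2=O)cc1`: > 4000 nM
Compound 3, `O=C1C(NC2CCCCC2)=CC(=O)c2c1nc1n2[C@H]2OC[C@@H](O)[C@H]2OC1`: > 16000 nM

Every value here is a limit of this assay and not a number. For compound 1 the value > 8000 nM is such a limit, as the limit of > 8000 nM in this assay, at which 1 of the 3 values shown sits, records. For compound 2 the value > 4000 nM is likewise a limit, as the limit of > 4000 nM in this assay, at which 1 of the 3 values shown sits, records. Compound 3 stands at a limit as well, > 16000 nM, as the limit of > 16000 nM in this assay, at which 1 of the 3 values shown sits, records, and the two other values shown are limits too, so compound 3 cannot be placed against them. The steps a step that the two limits leave unreadable from compound 1 to compound 2, a step that the two limits leave unreadable from compound 1 to compound 3 and a step that the two limits leave unreadable from compound 2 to compound 3 are all unreadable for the same reason.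

Compound 4, `O=C1C(Nc2ccccc2)=CC(=O)c2c1nc1n2[C@H]2OC[C@@H](O)[C@H]2OC1`, differs from compound 3 by phenyl in place of cyclohexyl on an amine nitrogen. The step most like it, a step that the two limits leave unreadable from compound 2 to compound 3, gives no readable size, so no step beyond the scatter in this assay can be expected in either direction. Compound 4 is therefore expected to give a limit again, an estimated 12000 nM within 2000 nM to 60000 nM, which would mean an expected step of an at least 1.3-fold lower number from compound 3 to compound 4 (0.12 log units; that floor lies within the scatter).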

Compound 4, half-maximal inhibitory concentration: 3560 nM
For compound 4 the middle estimate is 3.4-fold (0.53 log units) above the measured one; the measured number falls inside the stated range.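

With phenyl on the amine nitrogen, compound 4 is the only compound shown that gives a number and not a limit in this assay, and the change from cyclohexyl reads as an at least 4.4-fold lower number from compound 3 to compound 4 (0.65 log units; beyond the scatter). At the double-bonded ring carbon, anilino in place of piperidin-1-yl reads as an at least 2.2-fold lower number from compound 1 to compound 4 (0.35 log units; beyond the scatter), so the earlier limits now have a measured compound to be set against. Hydrogen in place of methyl on an aromatic carbon reads as an at least 1.1-fold lower number from compound 2 to compound 4 (0.05 log units; that floor lies within the scatter), which cannot be told from no change, because compound 2 stands at a limit: the limit of > 4000 nM in this assay, at which 1 of the 4 values shown sits.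

The compounds shown leave open whether a methoxy group or a carboxylic acid on the phenyl ring of compound 4 would keep or shift its value. They also leave open how a benzylamino group would read in place of anilino.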